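Aromatic-nitrogen substituent change: compound 3 to compound 4

The compounds below may be only part of what the source reports. "The series", "measured", "known", "first", "only" and "open" are said of these compounds alone.

Measured in an assay on Prostate gland for inhibition of steroid 5-alpha-reductase (Rattus norvegicus); on this read-out lower numbers stand for stronger inhibition and higher numbers for weaker inhibition:
compound 1 `CCCCCCn1ccc2cc(/C(C)=C/C(=O)Nc3ccccc3OCCCC(=O)O)ccc21` gives 77 nM
compound 2 `CCCC(C)n1ccc2cc(/C(C)=C/C(=O)Nc3ccccc3OCCCC(=O)O)ccc21` gives 7.8 nM
compound 3 `CCCCC(CCCC)n1ccc2cc(/C(C)=C/C(=O)Nc3ccccc3OCCCC(=O)O)ccc21` gives 21 nM

Compound 3 holds the second highest of the three numbers. Its nearest neighbour is compound 2, the gap being a 2.7-fold higher number from compound 2 to compound 3 (0.43 log units; beyond the scatter); its furthest is compound 1, the gap being a 3.7-fold lower number from compound 1 to compound 3 (0.56 log units; beyond the scatter).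

Compound 4 `C/C(=C\C(=O)Nc1ccccc1OCCCC(=O)O)c1ccc2c(ccn2Cc2ccccc2C)c1` differs from compound 3 in one place: 2-methylbenzyl in place of 1-butylpentyl on an aromatic nitrogen. All three measured steps concern the group on this same aromatic nitrogen, so they bear on the change, though only loosely: a 9.9-fold lower number from compound 1 to compound 2 (0.99 log units; beyond the scatter), a 3.7-fold lower number from compound 1 to compound 3 (0.56 log units; beyond the scatter) and a 2.7-fold higher number from compound 2 to compound 3 (0.43 log units; beyond the scatter). Among the measured compounds shown here, each is modest, and each exchanges one open chain for another; none brings in a ring, so no measured step tells the direction for a 2-methylbenzyl group. The spread of the measured numbers is itself narrow, so a change of similar size in either direction is plausible and neither is favoured.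

The step from compound 3 to compound 4 is therefore expected to stay within the scatter, a 1.4-fold higher number from compound 3 to compound 4 (0.15 log units; within the scatter). For compound 4 the estimated value in this assay is 30 nM, with a range from 8 nM to 120 nM.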

Compound 4, half-maximal inhibitory concentration: 69 nM
The estimate for compound 4 lay 2.3-fold (0.36 log units) below the measured number; low and high end bracket the measured number.
By their numbers in this assay, from the lowest: compound 2; then compound 3; then compounds 4 and 1 (each within the scatter of the next).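

In this assay, among the compounds shown here, the first group on this aromatic nitrogen to carry a ring, 2-methylbenzyl, does not reach the numbers of either branched chain (a 3.3-fold higher number from compound 3 to compound 4 (0.52 log units; beyond the scatter); an 8.8-fold higher number from compound 2 to compound 4 (0.95 log units; beyond the scatter)). Exchanging pentyl for 2-methylphenyl on the saturated chain carbon bound to an aromatic nitrogen cannot be told apart from no change (a 1.1-fold lower number from compound 1 to compound 4 (0.05 log units; within the scatter)), so among the four compounds shown, the ring and the straight chain sit together, and the two groups branched at that carbon, in compound 2 and compound 3, give the lower numbers, with no compound going against this. No supporting data are available to explain this grouping.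

The compounds shown leave open whether the 2-methyl group contributes anything, which plain benzyl would test, and whether an aromatic ring on a branched carbon, as in 1-phenylethyl, would behave like compound 2 and compound 3 or like compound 4. They also leave open how a saturated ring such as cyclohexyl, or a chain ending in an amine, would read at this position.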